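The source may report more compounds than this note shows. Statements on the series, on what has been measured and on what is new or still open speak of the compounds shown alone.

Compound 2 `COc1c(F)cccc1C1CCN(c2ccn3c(CC4CC4)nnc3c2Cl)CC1` was measured in an ADME assay on a cell-free system (plasma, Rattus norvegicus) for protein binding (on this read-out lower numbers stand for a smaller free fraction and higher numbers for a larger free fraction), where it gives < 0.01, which is a limit of the assay rather than a number. Compound 1 `COc1ccccc1C1CCN(c2ccn3c(CC4CC4)nnc3c2Cl)CC1` gives < 0.01 in this assay, again only a limit. The step that the two limits leave unreadable from compound 1 to compound 2 therefore cannot be read, since both values sit at the limit of < 0.01 in this assay, at which 2 of the 2 values shown sit. Compound 3 `COc1ccc(F)c(F)c1C1CCN(c2ccn3c(CC4CC4)nnc3c2Cl)CC1` carries the change (2,3-difluoro-6-methoxyphenyl in place of 3-fluoro-2-methoxyphenyl on a saturated ring carbon). Going by the values given here, with no measured step readable as a number, the step that the limit leaves unreadable from compound 2 to compound 3 is expected to stay within the usual scatter. Compound 3 is thus expected to give 0.005 in this assay, with a range from 0.002 to 0.012, most probably reported once more as a limit.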

Compound 3, unbound fraction: < 0.01
Compound 3 ended at the assay's limit; the forecaster's own chance of this, stated with the estimate: 85%; the middle value does not contradict the limit.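

No step between compound 1, compound 2 and compound 3 can be read in this assay, because each gives only a limit of the assay: the limit of < 0.01 in this assay, at which 3 of the 3 values shown sit.

The compounds shown leave open whether the fluoro changes alter the free fraction at all.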